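Amide series on the shared core: pyrrolyl for nitrophenoxy

This account rests on a few compounds, and the source may have more. Where it says the series, first, only, none or still open, it means among the compounds named here.

Compound 1 `COc1ccc(-c2cc(=O)c3c(OC)cc(OC)cc3n2S(=O)(=O)c2cc(Cl)cc(Cl)c2O)cc1` carries a sulfonyl substituent on the ring nitrogen rather than an amide. In a functional assay on SUP-B15 cells (Homo sapiens) for antiproliferative activity, with a stated time of 72 h (on this read-out lower numbers stand for an effect already at smaller amounts and higher numbers for an effect only at larger amounts of compound), compound 1 gives > 37900 nM, which is a limit of the assay and not a number. Compound 2 `COc1cc(OC)c2c(=O)cc(C(=O)Nc3ccc4oc(-c5ccc(F)cc5)nc4c3)[nH]c2c1` is an amide on the shared core. In this assay compound 2 gives > 36700 nM, again a limit rather than a number. Going by the values given here, compound 3 `COc1cc(OC)c2c(=O)cc(C(=O)Nc3ccc(Oc4ccc([N+](=O)[O-])cc4)cc3)[nH]c2c1` carries the 4-nitrophenoxy group, and in this assay compound 3 gives 4300 nM, the only measured number among the three. The two other entries sit at limits, the limit of > 36700 nM in this assay, at which 1 of the 3 values shown sits, and (the limit of > 37900 nM in this assay, at which 1 of the 3 values shown sits), so compound 3 is the sole anchor for the series.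

Compound 4 `COc1cc(OC)c2c(=O)cc(C(=O)Nc3ccc(-n4cccc4)cc3)[nH]c2c1` differs from compound 3 in one place: 1H-pyrrol-1-yl in place of 4-nitrophenoxy on an aromatic carbon. Among the compounds with values here, no step between two measured compounds is available to calibrate this change, and the smaller entering group leaves the direction uncertain. The step from compound 3 to compound 4 in this assay is expected to be a 2.1-fold higher number from compound 3 to compound 4 (0.32 log units; beyond the scatter), toward higher concentrations but of moderate size. For compound 4 the estimate in this assay is 9000 nM, within 2500 nM to 35000 nM.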

Compound 4, half-maximal effective concentration: > 77000 nM
Compound 4: a limit, no number (the forecaster's own chance of this, stated with the estimate: 30%); at least 8.5-fold (0.93 log units) between middle value and limit.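

In this assay, going by these compounds alone, replacing 4-nitrophenoxy with 1H-pyrrol-1-yl on the aromatic carbon gives an at least 17-fold higher number from compound 3 to compound 4 (1.25 log units; beyond the scatter), the first single-place comparison. Within the data shown here, of these two amides on the shared core, only the one carrying 4-nitrophenoxy gives a measured number, so the group at this position has a large bearing on the read-out. Compound 4 gives a limit of the assay, not a number: the limit of > 77000 nM in this assay, at which 1 of the 4 values shown sits.

The exchange changes the ring, the ether oxygen and the nitro group together, and this single pair cannot separate their contributions. A phenoxy group without the nitro group, or with an amine in its place, would show whether the number of compound 3 depends on the nitro group or on the phenoxy group itself.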